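The compounds below may be only part of what the source reports. "The series", "measured", "known", "first", "only" and "open" are said of these compounds alone.

Compound 2 `CCCOc1nc(C(C)(C)C)ccc1CNC(=O)C(C)c1ccc(NS(C)(=O)=O)c(F)c1` and compound 1 `CCCN(CCC)c1nc(C(C)(C)C)ccc1CNC(=O)C(C)c1ccc(NS(C)(=O)=O)c(F)c1` share one core and differ only at one aromatic carbon, where compound 2 carries propoxy and compound 1 dipropylamino. In an assay on cells for antagonist activity at transient receptor potential cation channel subfamily V member 1 (Homo sapiens), read by FLIPR and calcium flux, with a stated time of 6 min (a higher number here means a weaker inhibitor, a lower number a stronger inhibitor), compound 1 gives 2.5 nM, and compound 2 gives 1.7 nM, a step of a 1.5-fold lower number from compound 1 to compound 2 (0.17 log units; within the scatter), so the two numbers sit within the scatter of each other. Compound 3 `CCCCCCOc1nc(C(C)(C)C)ccc1CNC(=O)C(C)c1ccc(NS(C)(=O)=O)c(F)c1` differs from compound 2 by propyl in place of hydrogen on a saturated chain carbon, three bonds along the chain from an oxygen on an aromatic ring. Among the compounds with values here, no measured step lengthens this chain, so the one step seen gives no direct guide. The expectation is a step of a 1.8-fold higher number from compound 2 to compound 3 (0.25 log units; within the scatter), with compound 3 estimated at 3 nM, between 0.8 nM and 12 nM.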

Compound 3, inhibition constant: 2.7 nM
Beside the measured number, compound 3's estimate is 1.1-fold (0.05 log units) above it; the range from low to high includes it.
By their numbers in this assay, from the lowest: compounds 2, 1 and 3 (each within the scatter of the next).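

Changing propyl to hexyl on the oxygen gives a 1.6-fold higher number from compound 2 to compound 3 (0.20 log units; within the scatter) in this assay, so the added propyl does not move the number beyond the scatter. Hexyloxy in place of dipropylamino gives a 1.1-fold higher number from compound 1 to compound 3 (0.03 log units; within the scatter) and so also stays within the scatter, which means all three groups at this aromatic carbon read alike. No evidence here offers a reason for this.

As far as these compounds go, whether a longer chain such as decyloxy would still read alike remains open. So does the outcome for a hexyl chain carrying an amine or a carboxylic acid.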